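Enlarging a ring on the amine nitrogen of compound 3

A few compounds are considered here, and "the series" means these few. Any claim that something is new, unique, unknown or untested is made for them only; others in the source may bear on it.

Of the compounds shown here, three sharing one core have been measured in an in vitro functional assay on cells for antagonist activity at B1 bradykinin receptor (Homo sapiens), read by luminescence and calcium flux, with a stated time of 2 h; on this read-out lower numbers stand for stronger inhibition and higher numbers for weaker inhibition. Compound 1 `Cc1ccc(S(=O)(=O)N2C=CNC(=O)[C@H]2CC(=O)N[C@H]2CCN(CC(C)(C)C)CC2(C)C)cc1` gives 1.38 nM. Compound 2 `Cc1ccc(S(=O)(=O)N2C=CNC(=O)[C@H]2CC(=O)N[C@H]2CCN(Cc3ccccc3)CC2(C)C)cc1` gives 1.09 nM. For the measured compounds named here, compound 3 `Cc1ccc(S(=O)(=O)N2C=CNC(=O)[C@H]2CC(=O)N[C@H]2CCN(C3CCC3)CC2(C)C)cc1` gives 0.74 nM, the lowest of the three numbers, though its nearest neighbour is compound 2, with a 1.5-fold lower number from compound 2 to compound 3 (0.17 log units; within the scatter), and its furthest is compound 1, with a 1.9-fold lower number from compound 1 to compound 3 (0.27 log units; within the scatter), so no compound can be set apart from the others.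

Compound 4 `Cc1ccc(S(=O)(=O)N2C=CNC(=O)[C@H]2CC(=O)N[C@H]2CCN(C3CCCC3)CC2(C)C)cc1` differs from compound 3 in one place: cyclopentyl in place of cyclobutyl on an amine nitrogen in a ring. Going by the values given here, the steps that bear on this change are those that altered the same amine nitrogen: a 1.9-fold lower number from compound 1 to compound 3 (0.27 log units; within the scatter) and a 1.5-fold lower number from compound 2 to compound 3 (0.17 log units; within the scatter), and also a 1.3-fold lower number from compound 1 to compound 2 (0.10 log units; within the scatter) at the neighbouring chain carbon. All three stayed within the scatter, across groups as different as neopentyl, benzyl and cyclobutyl. The move to cyclopentyl is smaller than any of those, so the step of a 1.1-fold higher number from compound 3 to compound 4 (0.03 log units; within the scatter) is expected to lie within the scatter as well, with no clear direction. Compound 4 is therefore estimated at 0.8 nM in this assay, with a range from 0.35 nM to 1.8 nM.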

Compound 4, half-maximal inhibitory concentration: 0.247 nM
The estimate for compound 4 lay 3.2-fold (0.51 log units) above the measured number; the whole stated range lies above it.
By their numbers in this assay, from the lowest: compound 4; then compounds 3, 2 and 1 (each within the scatter of the next).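

In this assay the groups on the amine nitrogen in the ring had until now stayed within the scatter of one another, and cyclopentyl is the only one of the four to separate from the rest, with a 3.0-fold lower number from compound 3 to compound 4 (0.48 log units; beyond the scatter) and a 4.4-fold lower number from compound 2 to compound 4 (0.64 log units; beyond the scatter) and also a 5.6-fold lower number from compound 1 to compound 4 (0.75 log units; beyond the scatter) as its steps. The smallest of these changes in atoms, one added ring carbon that turns a four-membered carbon ring into a five-membered one with no hydrogen-bond donor or acceptor on either side, therefore gives a modest step, while the larger exchanges among neopentyl, benzyl and cyclobutyl gave none beyond the scatter. Nothing available explains why this one carbon makes a difference here.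

Going by these compounds, it remains open whether the numbers keep falling with cyclohexyl or rise again with it, and how cyclopropyl or a ring carrying an oxygen, such as tetrahydropyranyl, would compare at this nitrogen. On these data alone, it is also open whether the step from cyclobutyl to cyclopentyl would hold on a core without the two methyl groups on the ring atom that bears them.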